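This account rests on a few compounds, and the source may have more. Where it says the series, first, only, none or still open, it means among the compounds named here.

Compound 2 `Cc1c(OCCCCOc2ccc(C(=O)O)cc2)ccc(C(=O)CC(C)C)c1O` gives 51.9% in an assay on HEK293 cells for positive allosteric modulation of metabotropic glutamate receptor 3 (Rattus norvegicus), read by thallium flux, with a stated time of 2.5 min; on this read-out lower numbers stand for smaller maximal responses and higher numbers for larger maximal responses. Among the compounds with values here, compound 1 `Cc1c(OCCCCOc2ccc(C(=O)O)cc2)ccc(C(=O)CC2CCCC2)c1O` gives 26.7% in this assay; the single change between them, (cyclopentyl in place of isopropyl on a saturated chain carbon bound to a carbonyl carbon), produces a number 25.2 percentage points lower from compound 2 to compound 1 (beyond the scatter). Compound 3 `Cc1c(OCCCCOc2ccc(F)c(C(=O)O)c2)ccc(C(=O)CC(C)C)c1C` gives 13.8% in this assay, the lowest of the three numbers, with compound 1 nearest and compound 2 furthest; the difference between the core of compound 3 and the core of compound 2 is not broken down here. Compound 4 `Cc1c(OCCCCOc2ccc(F)c(C(=O)O)c2)ccc(C(=O)CC2CCCC2)c1C` is not yet measured in this assay; it differs from compound 3 by cyclopentyl in place of isopropyl on a saturated chain carbon bound to a carbonyl carbon, the same change as from compound 2 to compound 1. Because compound 3 already gives 13.8%, the expected step is smaller than the earlier one, the read-out having little room left downward: the expected step is a number 7.8 percentage points lower from compound 3 to compound 4 (within the scatter). Compound 4 is estimated at 6%, expected between 0% and 20%.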

Compound 4, largest response reached (reported as percent of maximum), in percent of the reference or control that the assay uses: 12.6%
Beside the measured number, compound 4's estimate is 6.6 percentage points below it; low and high end bracket the measured number.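

On the core of compound 3, cyclopentyl in place of isopropyl gives a number 1.2 percentage points lower from compound 3 to compound 4 (within the scatter) in this assay. The step does not keep its size from one core to the other: the same change on two cores in this assay, a number 25.2 percentage points lower (beyond the scatter) from compound 2 to compound 1 and a number 1.2 percentage points lower (within the scatter) from compound 3 to compound 4, 24 percentage points apart, beyond the scatter of two such steps This shows that the effect of the change depends on the core in these two pairs, but it does not show which difference between the cores matters, nor whether the small step merely reflects the low starting value of compound 3, 13.8%.

Still open, as far as these compounds go, is how the change behaves on a core that differs from the core of compound 2 in one place only. Also open, from the compounds shown here alone, is whether a cyclohexyl or a phenyl in this place follows the cyclopentyl result on either core.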